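The source may report more compounds than this note shows. Statements on the series, on what has been measured and on what is new or still open speak of the compounds shown alone.

Compound 1, `Nc1cc(Oc2ccc(NC(=O)Nc3cccc(C(F)(F)F)c3)cc2)ncn1`: in an assay on isolated protein for inhibition of serine/threonine-protein kinase TNNI3K (Homo sapiens) (a lower number here means a stronger inhibitor, a higher number a weaker inhibitor), compound 1 gives 25 nM. Compound 2, `O=C(Nc1ccc(Oc2ccncn2)cc1)Nc1cccc(C(F)(F)F)c1`: compound 2 gives 160 nM. Compound 3, `CNc1cc(Oc2ccc(NC(=O)Nc3cccc(C(F)(F)F)c3)cc2)ncn1`: compound 3 gives 40 nM.

Compound 3 stands second highest of the three numbers; its gap to compound 1 is within the scatter, its gap to compound 2 is beyond it. Compound 4, `O=C(Nc1ccc(Oc2cc(O)ncn2)cc1)Nc1cccc(C(F)(F)F)c1`, differs from compound 3 by hydroxy in place of methylamino on an aromatic carbon. For the measured compounds named here, the steps that bear on this are a 4.0-fold lower number from compound 2 to compound 3 (0.60 log units; beyond the scatter) and a 6.4-fold higher number from compound 1 to compound 2 (0.81 log units; beyond the scatter), both showing that a donor-bearing group at this carbon matters, while a 1.6-fold higher number from compound 1 to compound 3 (0.20 log units; within the scatter) shows the methyl itself counts little. Since hydroxy keeps one donor and one acceptor, compound 4 is expected to sit near compound 3, with a step of about a 1.5-fold higher number from compound 3 to compound 4 (0.18 log units; within the scatter); the estimate for compound 4 is 60 nM, ranging from 25 nM to 160 nM.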

Compound 4, half-maximal inhibitory concentration: 3200 nM
Compound 4: the middle estimate sits 53-fold (1.73 log units) below what was measured; the measured number lies above the stated range.
By their numbers in this assay, from the lowest: compounds 1 and 3 (each within the scatter of the next); then compound 2; then compound 4.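

In this assay, the counts of one donor and one acceptor do not decide the outcome at this carbon, since hydroxy and methylamino share them and yet the change gives an 80-fold higher number from compound 3 to compound 4 (1.90 log units; beyond the scatter) here. Hydroxy in place of amino gives a 130-fold higher number from compound 1 to compound 4 (2.11 log units; beyond the scatter) in the same direction, and even hydrogen does better, with a 20-fold higher number from compound 2 to compound 4 (1.30 log units; beyond the scatter) showing hydroxy as the only group here that gives a higher number than hydrogen. No measurement at hand explains this difference between the groups. The compounds shown leave open how methoxy or dimethylamino would fare at this carbon. They also leave open whether a longer chain on the amine nitrogen would hold the number of compound 3.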